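Acetyl in Place of Methyl on the Ring Oxygen

This account rests on a few compounds, and the source may have more. Where it says the series, first, only, none or still open, it means among the compounds named here.

For the measured compounds named here, in an assay on RBL-1 cells with Polyunsaturated fatty acid 5-lipoxygenase (Rattus norvegicus) as the target (a higher number here means a weaker inhibitor, a lower number a stronger inhibitor), compound 2 `COc1c(Cc2ccccc2)ccc2ccccc12` gives 55000 nM, the higher of the two numbers measured so far. Compound 1 `Oc1c(Cc2cccc(Oc3ccccc3)c2)ccc2ccccc12` gives 83 nM in this assay, but it differs from compound 2 in two places, so no single change can be credited with that gap. Compound 3 `CC(=O)Oc1c(Cc2ccccc2)ccc2ccccc12` is compound 2 with acetyl in place of methyl on an oxygen on an aromatic ring. Going by the values given here, no measured pair isolates this change, so its size is open. A modest improvement is expected, a 6.9-fold lower number from compound 2 to compound 3 (0.84 log units; beyond the scatter), though staying within the scatter is possible. Compound 3 is estimated at 8000 nM, between 800 nM and 50000 nM.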

Compound 3, half-maximal inhibitory concentration: 140 nM
Compound 3: middle estimate off by 57-fold (1.76 log units), on the high side, and the stated range ends above it.
By their numbers in this assay, from the lowest: compounds 1 and 3 (each within the scatter of the next); then compound 2.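

In this assay, replacing methoxy with acetoxy on the shared core gives a 390-fold lower number from compound 2 to compound 3 (2.59 log units; beyond the scatter) with nothing else altered. For the compounds shown here, this is the first single change that can be read on its own, and it shows that the group on this ring oxygen strongly affects the measured number. No available evidence explains why this step is so large. On these data alone, whether a longer acyl group such as propanoyl or a benzoyl group would match acetyl on this oxygen remains open, as does whether the same change would carry over to the core of compound 1.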